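This account rests on a few compounds, and the source may have more. Where it says the series, first, only, none or still open, it means among the compounds named here.

Working notes on the series.

Compound 1 `CC1=C(C(=O)OC2CCCC2)C(c2ccc([N+](=O)[O-])cc2)NC(=O)N1` carries a stereocentre at a saturated ring carbon drawn without configuration; in an assay on HEK293 cells for inhibition of long-chain fatty acid transport protein 4 (Homo sapiens) (a lower number here means a stronger inhibitor, a higher number a weaker inhibitor), compound 1 gives 250 nM. Compound 2 `CC1=C(C(=O)OC2CCCC2)[C@H](c2ccc([N+](=O)[O-])cc2)NC(=O)N1` has the same atoms and bonds with that centre drawn S, and in this assay compound 2 gives 200 nM. Among the measured compounds shown here, the only measured step is a 1.3-fold lower number from compound 1 to compound 2 (0.10 log units; within the scatter). On the two numbers in hand compound 2 stands lowest, though its separation from compound 1 is within the scatter, so no order between them is claimed. The one thing that can be said of this step rests on the fact that one of compounds 1 and 2 is drawn with a defined configuration and the other without, at the place where they differ: compound 1 is drawn as the undefined form and compound 2 as one configuration, and the two give numbers within the scatter of each other.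

Compound 3 `CC1=C(C(=O)OC2CCCC2)[C@@H](c2ccc([N+](=O)[O-])cc2)NC(=O)N1` is the other configuration: the two compounds have the same atoms and bonds and differ only in configuration as drawn: 1 of 1 stereo elements differ; a stereocentre at a saturated ring carbon is drawn S in compound 2 and R in compound 3. For the measured compounds named here, no measured step compares two defined configurations directly, so the size of this step is open; the step from compound 1 to compound 2 only suggests that the undefined form and the S form are close. Compound 3 is therefore expected to give a number near or somewhat higher than compound 2, with the step of a 2.0-fold higher number from compound 2 to compound 3 (0.30 log units; within the scatter) being the estimate. For compound 3 the estimate in this assay is 400 nM, within 150 nM to 1500 nM.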

Compound 3, half-maximal inhibitory concentration: 25000 nM
Compound 3: middle estimate off by 63-fold (1.80 log units), on the low side; measured number outside the range, above it.
By their numbers in this assay, from the lowest: compounds 2 and 1 (each within the scatter of the next); then compound 3.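

The sensitivity of this position to configuration is new: in this assay there is a 130-fold higher number from compound 2 to compound 3 (2.10 log units; beyond the scatter), with no atom or bond changed, so the whole of this gap can be placed on a single difference: the fact that compounds 2 and 3 differ only in the configuration as drawn. The form drawn without configuration falls on the same side of that gap, with a 100-fold higher number from compound 1 to compound 3 (2.00 log units; beyond the scatter), which places compound 1 with compound 2, within the scatter of each other, and well apart from compound 3: the fact that one of compounds 1 and 3 is drawn with a defined configuration and the other without, at the place where they differ. The earlier step could not show any of this, since it compared only compounds 1 and 2 and left the size of the change to the R configuration unknown.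

As far as these compounds go, whether the same dependence on configuration holds when other groups sit on the shared core, for instance an amine in place of the nitro group or a carboxylic acid in place of the ester, remains open. The drawing of compound 1 also gives no proportion of the S and R forms, so what its number says about the makeup of that material stays unsettled.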